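The compounds below may be only part of what the source reports. "The series", "measured", "known", "first", "only" and "open" are said of these compounds alone.

Compound 1 `CC[C@H](C)C(=O)O[C@H]1C[C@@H](C)C=C2C=C[C@H](C)[C@H](CC[C@@H](O)C[C@@H](CC(=O)NO)OC(=O)c3ccc(OC(F)(F)F)cc3)[C@H]21` is one of three closely related compounds tested in a functional assay on PC-3 cells (Homo sapiens) for inhibition, read by sulforhodamine B assay, with a stated time of 48 h; a higher number here means a weaker inhibitor, a lower number a stronger inhibitor. In this assay compound 1 gives 20300 nM, the second highest of the three numbers. Its nearest companion is compound 2 `CC[C@H](C)C(=O)O[C@H]1C[C@@H](C)C=C2C=C[C@H](C)[C@H](CC[C@@H](O)C[C@@H](CC(=O)NO)OC(=O)c3ccc(Cl)cc3)[C@H]21`, which in this assay gives 21700 nM; the step is a 1.1-fold higher number from compound 1 to compound 2 (0.03 log units; within the scatter), the change being a chloro in place of the trifluoromethoxy on an aromatic carbon. Compound 3 `CC[C@H](C)C(=O)O[C@H]1C[C@@H](C)C=C2C=C[C@H](C)[C@H](CC[C@@H](O)C[C@@H](CC(=O)NO)OC(=O)c3ccc4ccccc4c3)[C@H]21` gives 17300 nM in this assay, a step of a 1.2-fold lower number from compound 1 to compound 3 (0.07 log units; within the scatter), with a naphthalen-2-yl in place of the 4-(trifluoromethoxy)phenyl on a carbonyl carbon. Between compound 2 and compound 3 the step is a 1.3-fold lower number from compound 2 to compound 3 (0.10 log units; within the scatter). All three steps alter the group attached to that carbonyl carbon of the shared core, and none reaches beyond the scatter.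

Compound 4 `CC[C@H](C)C(=O)O[C@H]1C[C@@H](C)C=C2C=C[C@H](C)[C@H](CC[C@@H](O)C[C@@H](CC(=O)NO)OC(=O)CCc3ccccc3)[C@H]21` keeps the same core and differs from compound 1 at that same place: phenethyl in place of 4-(trifluoromethoxy)phenyl on a carbonyl carbon. The three measured steps each swap the group on that carbonyl carbon and each stayed within the scatter, so they bear directly on this change. No step beyond the scatter is expected in this assay. For compound 4 the expected step is a 1.0-fold lower number from compound 1 to compound 4 (0.01 log units; within the scatter). Compound 4 is therefore estimated at 20000 nM in this assay, within a range from 9000 nM to 45000 nM.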

Compound 4, half-maximal inhibitory concentration: 6200 nM
Beside the measured number, compound 4's estimate is 3.2-fold (0.51 log units) above it, outside the stated range (below it).
By their numbers in this assay, from the lowest: compound 4; then compounds 3, 1 and 2 (each within the scatter of the next).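

Changing the group on this carbonyl carbon can shift the result in this assay after all, as the phenethyl group gives a 3.3-fold lower number from compound 1 to compound 4 (0.52 log units; beyond the scatter) and a 2.8-fold lower number from compound 3 to compound 4 (0.45 log units; beyond the scatter) and also a 3.5-fold lower number from compound 2 to compound 4 (0.54 log units; beyond the scatter) as modest steps, which makes compound 4 the strongest inhibitor of the four. Among these compounds, the earlier compounds showed only that exchanging one aromatic group attached directly to the carbonyl carbon for another left the number within the scatter, whereas phenethyl is the first group here that reaches this carbon through a carbon chain rather than through its ring. Nothing shown here explains why this change lowers the number.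

Compound 4 differs from the others in two ways at once, since it has the chain and its ring carries no chloro or trifluoromethoxy group, and so the compounds shown cannot say which of the two matters. A plain phenyl group on the carbonyl carbon would separate these two features, while benzyl and 3-phenylpropyl groups would show how the number follows a shorter or longer chain, and none of these three groups is among the compounds shown.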